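The source may report more compounds than this note shows. Statements on the series, on what has been measured and on what is new or still open speak of the compounds shown alone.

Working notes on the series, all read in a functional assay on HOS cells (Homo sapiens) for antiproliferative activity, read by sulforhodamine B assay (on this read-out higher numbers stand for weaker inhibition of growth and lower numbers for stronger inhibition of growth), throughout. Compound 1 (`O[C@H]1CO[C@H](COCc2ccccc2)[C@@H](OCc2ccccc2)[C@@H]1OCc1ccccc1`) gives 37900 nM in this read-out, compound 2 (`OC[C@@H]1O[C@H](COCc2ccccc2)[C@@H](OCc2ccccc2)[C@H](OCc2ccccc2)[C@H]1O`) gives 27300 nM and compound 3 (`OCC[C@@H]1O[C@H](COCc2ccccc2)[C@@H](OCc2ccccc2)[C@H](OCc2ccccc2)[C@H]1O`) gives 39700 nM on the same scale. All three values lie within the scatter of one another, so compound 3 stands level with the other two on these numbers.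

Compound 4 (`O[C@@H]1[C@@H](OCc2ccccc2)[C@H](OCc2ccccc2)[C@@H](COCc2ccccc2)O[C@H]1Cc1ccccc1`) is the next entry and differs from compound 3 as follows: phenyl in place of hydroxymethyl on a saturated chain carbon bound to a saturated ring carbon. In words, this is phenyl in place of hydroxymethyl on a saturated chain carbon bound to a saturated ring carbon, which also reads as 2-hydroxyethyl to benzyl.

Going by the values given here, three measured steps bear on this change: a 1.4-fold lower number from compound 1 to compound 2 (0.14 log units; within the scatter), a 1.0-fold higher number from compound 1 to compound 3 (0.02 log units; within the scatter) and a 1.5-fold higher number from compound 2 to compound 3 (0.16 log units; within the scatter). All three stay within the scatter. Among the compounds with values here, none of them places an aromatic ring at this position, so the data hold no direct precedent and the range has to stay wide. Given the small size of a 1.5-fold higher number from compound 2 to compound 3 (0.16 log units; within the scatter) and of the other two steps, no change beyond the scatter is expected in this assay for this swap. The expected step is a 1.6-fold lower number from compound 3 to compound 4 (0.20 log units; within the scatter). For compound 4 the estimated value is 25000 nM, with an expected range from 10000 nM to 60000 nM.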

Compound 4, concentration for 50% growth inhibition: 29200 nM
Compound 4: the middle estimate sits 1.2-fold (0.07 log units) below what was measured, within the range that was stated.
By their numbers in this assay, from the lowest: compounds 2, 4, 1 and 3 (each within the scatter of the next).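

In this assay, the first aromatic ring at this place, on a saturated chain carbon bound to a saturated ring carbon, leaves the read-out level with the compounds that carry no ring there. This holds for phenyl in place of hydroxymethyl (a 1.4-fold lower number from compound 3 to compound 4 (0.13 log units; within the scatter)), for phenyl in place of hydroxy (a 1.1-fold higher number from compound 2 to compound 4 (0.03 log units; within the scatter)) and for benzyl in place of hydrogen on a saturated ring carbon (a 1.3-fold lower number from compound 1 to compound 4 (0.11 log units; within the scatter)). Across compounds 1 to 4, then, hydrogen, hydroxymethyl, 2-hydroxyethyl and benzyl cannot be told apart at this position, and the hydroxy group of 2-hydroxyethyl can go, with 0 hydrogen-bond donors in the entering phenyl, without a step beyond the scatter, though no measurement at hand gives a reason for this flat picture.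

Still open, from the compounds shown here alone, is whether an amine, a carboxylic acid or a longer chain such as 3-phenylpropyl at this position would also stay within the scatter or would finally move the number. Also open, going by these compounds, is what the benzyloxy groups on the shared core contribute, since all four compounds carry them unchanged and their replacement by methoxy or hydroxy cannot be judged from these values.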